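This account rests on a few compounds, and the source may have more. Where it says the series, first, only, none or still open, it means among the compounds named here.

Compound 3, `Cc1ccc(-c2cc3c(=N)n(N)c(=S)[nH]c3n2-c2ccccc2)cc1`, gives 0% in a functional assay on the whole organism for inhibition, with Rattus norvegicus as the target, read by ELISA, with stated times of 30 min and 6 h, at a dose of 30 mg/kg by the oral route (a lower number here means less inhibition, a higher number more inhibition at the dose given (going by the name of the read-out)), the lowest of the three numbers in hand. Compound 2, `N=c1c2cc(-c3ccccc3)n(-c3ccccc3)c2[nH]c(=S)n1N`, gives 23%; compound 1, `CCn1c(=S)[nH]c2c(cc(-c3ccc(Br)cc3)n2-c2ccccc2)c1=N`, gives 80%. For the measured compounds named here, the step of a number 23 percentage points lower from compound 2 to compound 3 (beyond the scatter) is the one measured change, and it is beyond the scatter. Compound 4, `N=c1c2cc(-c3ccc(Br)cc3)n(-c3ccccc3)c2[nH]c(=S)n1N`, is reached from compound 3 by bromo in place of methyl on an aromatic carbon. Going by the values given here, no measured step covers bromo in place of methyl on this ring, and compound 1, though it carries the same 4-bromophenyl as compound 4, differs from it elsewhere, so its high number can only be read as a hint and not as a step. The step from compound 2 to compound 3 shows that the para group on this ring matters, so a change there is expected to move the number, but the direction for bromo is not pinned down. A moderate rise is estimated, a number 30 percentage points higher from compound 3 to compound 4 (beyond the scatter), with compound 4 expected at 30%, in the range 0% to 65%.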

Compound 4, a percentage reported as inhibition, in the whole organism at one dose (the size of the read-out at that dose, not a potency): 33%
The estimate for compound 4 lay 3 percentage points below the measured number; the measured number falls inside the stated range.
By their numbers in this assay, from the lowest: compound 3; then compounds 2 and 4 (each within the scatter of the next); then compound 1.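

In this assay the change from 4-methylphenyl to 4-bromophenyl gives a number 33 percentage points higher from compound 3 to compound 4 (beyond the scatter) and so shows that the low number of compound 3 goes with the methyl, not with the shared core. Bromo in place of hydrogen at this place gives a number 10 percentage points higher from compound 2 to compound 4 (within the scatter) so that, among the three groups seen here, only methyl stands apart. With the 4-bromophenyl held fixed, amino in place of ethyl on the aromatic nitrogen gives a number 47 percentage points lower from compound 1 to compound 4 (beyond the scatter) which ties the high number of compound 1 to its ethyl and not to its bromo.

From the compounds shown here alone, whether a methoxy or a chloro on this ring, or a propyl chain on that nitrogen, would follow these numbers stays open. Nothing at hand bears on why the numbers differ.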